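Amino for Dimethylamino: An Estimate for Compound 4

A few compounds are considered here, and "the series" means these few. Any claim that something is new, unique, unknown or untested is made for them only; others in the source may bear on it.

Measured so far:
- compound 1, `CN(C)c1cccc(S(=O)(=O)[N-][N+](=O)[O-])c1`, in an ADME assay on isolated protein for inhibition of carbonic anhydrase 4 (Homo sapiens), read by stopped-flow, with a stated time of 15 min (a lower number here means a stronger inhibitor, a higher number a weaker inhibitor), gives 4500 nM
- compound 2, `Nc1cccc(S(=O)(=O)[N-][N+](=O)[O-])c1`, in this assay gives 4300 nM
- compound 3, `CN(C)c1ccc(S(=O)(=O)[N-][N+](=O)[O-])cc1`, in this assay gives 11000 nM

Compound 1 and compound 2 share a core and differ in one place: amino in place of dimethylamino on an aromatic carbon. That change made a 1.0-fold lower number from compound 1 to compound 2 (0.02 log units; within the scatter), so compound 1 and compound 2 cannot be told apart in this assay.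

Compound 3 has the same atoms as compound 1, joined differently; the difference between the two cores is not broken down here. In this assay compound 3 stands at the highest number of the three, and the gap to compound 1 and to compound 2 lies beyond the scatter, so compound 3 is the weakest inhibitor measured.

Compound 4, `Nc1ccc(S(=O)(=O)[N-][N+](=O)[O-])cc1`, has not yet been measured. It differs from compound 3 by the same kind of change that separates compound 1 from compound 2: amino in place of dimethylamino on an aromatic carbon. The two places are not the same word for word: in compound 1 the group sits meta to a group of 7 heavy atoms, in compound 3 it sits para to a group of 7 heavy atoms. The expectation rests on compound 1 and compound 2, where the step of a 1.0-fold lower number from compound 1 to compound 2 (0.02 log units; within the scatter) was within the scatter. The step from compound 3 to compound 4 is expected to be no change at the digits printed from compound 3 to compound 4 (within the scatter). Compound 4 is therefore estimated at 11000 nM, with a range of 5000 nM to 25000 nM, because the starting point is compound 3 at 11000 nM.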

Compound 4, inhibition constant: 23600 nM
Compound 4: middle estimate off by 2.1-fold (0.33 log units), on the low side; low and high end bracket the measured number.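

In this assay, putting amino in place of dimethylamino on the second core gave a 2.1-fold higher number from compound 3 to compound 4 (0.33 log units; beyond the scatter), which means a modest loss of inhibition, while the same change had left the number unmoved on the first core. Read side by side, these two results do not show that the change behaves differently on the two cores, since the gap between them is no larger than two such steps can differ by chance: the same change on two cores in this assay, a 1.0-fold lower number (0.02 log units; within the scatter) from compound 1 to compound 2 and a 2.1-fold higher number (0.33 log units; beyond the scatter) from compound 3 to compound 4, 2.2-fold (0.35 log units) apart, within the scatter of two such steps What this supports is a cautious statement: across these two cores the change has so far produced either no detectable shift or a modest rise in the number, but two pairs are too few to give a reliable size for the step on a further core, and they do not explain why one step clears the scatter and the other does not.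

The compounds shown carry only amino or dimethylamino on the ring, so it remains open how a group such as methylamino, a carboxylic acid or a longer chain in that place would read in this assay. Also open, from the compounds shown here alone, is whether the step would repeat on a third core, which would help show whether the two results differ at all.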